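Exchanging the chloroindazolyl group of compound 1

A few compounds are considered here, and "the series" means these few. Any claim that something is new, unique, unknown or untested is made for them only; others in the source may bear on it.

Compound 1 `O=C(Nc1ccc(-n2ncc3c(Cl)cccc32)cc1)Nc1ccc(Cl)c(C(F)(F)F)c1` gives 1900 nM in a functional assay on HepG2 cells (Homo sapiens) for cytotoxicity, read by MTT assay, with a stated time of 72 h (on this read-out higher numbers stand for weaker inhibition and lower numbers for stronger inhibition), the second highest of the three numbers measured. Compound 2 `O=C(Nc1ccc(-n2ncc3c(C(F)(F)F)cccc32)cc1)Nc1ccc(C(F)(F)F)cc1` gives 1000 nM in this assay, within the scatter of compound 1, while compound 3 `O=C(Nc1ccc(-n2ncc3c(Cl)cccc32)cc1)Nc1ccc(C(F)(F)F)cc1` gives 6700 nM, the highest number of the set. Among the compounds with values here, the only single-point step available, a 6.7-fold higher number from compound 2 to compound 3 (0.83 log units; beyond the scatter), concerns a different change, chloro in place of trifluoromethyl on an aromatic carbon. Within the data shown here, compound 4 `O=C(Nc1ccc(-n2ncc3ccncc32)cc1)Nc1ccc(Cl)c(C(F)(F)F)c1` differs from compound 1 by a group of 9 heavy atoms (6 carbon, 3 nitrogen; one five-membered aromatic ring with 2 hetero atoms, one six-membered aromatic ring with 1 hetero atom) in place of a group of 10 heavy atoms (7 carbon, 2 nitrogen, 1 chlorine; one five-membered aromatic ring with 2 hetero atoms, one six-membered aromatic ring of carbon only), on an aromatic carbon, a change that no measured pair reproduces. Among the measured compounds shown here, with no directly comparable step, the account expects no shift beyond the scatter, a 1.3-fold higher number from compound 1 to compound 4 (0.12 log units; within the scatter). Compound 4 is therefore estimated at 2500 nM in this assay, between 900 nM and 7000 nM.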

Compound 4, half-maximal inhibitory concentration: 16000 nM
The estimate for compound 4 lay 6.4-fold (0.81 log units) below the measured number, outside the stated range (above it).
By their numbers in this assay, from the lowest: compounds 2 and 1 (each within the scatter of the next); then compound 3; then compound 4.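

In this assay, the exchange of the 4-chloro-1H-indazol-1-yl group gives an 8.4-fold higher number from compound 1 to compound 4 (0.93 log units; beyond the scatter). The earlier step concerned only a chloro and trifluoromethyl exchange on an aromatic carbon, whereas this one shows that replacing the whole group, on an aromatic carbon para to a large group, also moves the number beyond the scatter. No measurement given here explains this shift. The change removes chlorine and also puts a hetero atom into the six-membered ring, and the step cannot separate the two. Hydrogen in place of chlorine on the leaving group, or chlorine added to the entering group, remains open.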